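The source may report more compounds than this note shows. Statements on the series, on what has been measured and on what is new or still open speak of the compounds shown alone.

The measured compounds and their values in a functional assay on C6 cells (Rattus norvegicus) for cytotoxicity, read by MTT assay, with a stated time of 24 h, tested at 6 ug/mL; a lower number here means a stronger effect, a higher number a weaker effect of the compound at the concentration tested:
compound 1, `Cc1ccc(-c2cs/c(=N/NC(=O)CSc3nnnn3-c3ccccc3)n2-c2ccccc2)cc1`, giving 66.8%
compound 2, `Cc1ccc(-c2cs/c(=N/NC(=O)CSc3nncn3C)n2-c2ccccc2)cc1`, giving 74.6%
compound 3, `Cn1cnnc1SCC(=O)N/N=c1/scc(-c2ccc(C#N)cc2)n1-c1ccccc1`, giving 70.2%

Among these three numbers compound 2 stands highest, yet its nearest neighbour compound 3 sits only a number 4.4 percentage points lower from compound 2 to compound 3 (within the scatter) and its furthest neighbour compound 1 only a number 7.8 percentage points higher from compound 1 to compound 2 (within the scatter), so the three values are indistinguishable within the scatter of this assay.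

Compound 4, `Cc1ccc(-c2cs/c(=N/NC(=O)CSc3nnc(C)s3)n2-c2ccccc2)cc1`, has not yet been measured. It arises from compound 2 by the change (5-methyl-1,3,4-thiadiazol-2-yl in place of 4-methyl-4H-1,2,4-triazol-3-yl on a sulfur). Within the data shown here, only one measured step bears on this kind of change: the exchange of one five-membered heterocycle for another on the same sulfur, from compound 1 to compound 2, which gave a number 7.8 percentage points higher from compound 1 to compound 2 (within the scatter), a step within the scatter. The other step, the cyano in place of methyl on an aromatic carbon from compound 2 to compound 3, concerns a different part of the molecule and also stayed within the scatter. On this basis no step beyond the scatter is expected in this assay for the change to compound 4, in either direction.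

Compound 4 is therefore estimated at 72%, with a range from 60% to 84%. The expected step from compound 2 is a number 2.6 percentage points lower from compound 2 to compound 4 (within the scatter).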

Compound 4, a percentage reported as activity, at one concentration (the size of the read-out at that concentration, not a potency): 65.9%
Beside the measured number, compound 4's estimate is 6.1 percentage points above it; the range from low to high includes it.
By their numbers in this assay, from the lowest: compounds 4, 1, 3 and 2 (each within the scatter of the next).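

In this assay, 5-methyl-1,3,4-thiadiazol-2-yl in place of 4-methyl-4H-1,2,4-triazol-3-yl on a sulfur gives a number 8.7 percentage points lower from compound 2 to compound 4 (within the scatter) and in place of 1-phenyl-1H-tetrazol-5-yl gives a number 0.9 percentage points lower from compound 1 to compound 4 (within the scatter) at this same position. The sulfur, whose other neighbour is a saturated chain carbon, now carries three different five-membered aromatic rings in compounds 1, 2 and 4, and a ring sulfur entering with the same counts of heavy atoms and hydrogen-bond acceptors as the 4-methyl-4H-1,2,4-triazol-3-yl group leaves the reading within the scatter of both neighbours. No independent measurement is available that could account for how these rings read in this assay.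

On these data alone, whether this tolerance extends to groups other than five-membered aromatic rings on the same sulfur, such as a simple ethyl chain, an aminoethyl chain or a carboxymethyl group, remains open. As far as these compounds go, it is also open whether cyano in place of methyl on an aromatic carbon would read the same with 5-methyl-1,3,4-thiadiazol-2-yl on the sulfur as it does in compound 3.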